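The source may report more compounds than this note shows. Statements on the series, on what has been measured and on what is new or still open speak of the compounds shown alone.

Working notes on a small amide series with a shared core, followed in a functional assay on B16-F1 cells (Mus musculus) for antiproliferative activity, read by sulforhodamine B assay, with a stated time of 48 h; a higher number here means a weaker inhibitor, a lower number a stronger inhibitor. Compound 1 `CCCCCCCCCCNC(=O)c1c[nH]c(-c2ccccc2)n1` stands at > 30000 nM and this is a limit of the assay, not a number. Going by the values given here, compound 2 `CCCCCCCCCCCCNC(=O)c1c[nH]c(-c2ccccc2)n1` gives 30000 nM and this is the only true number so far, so it has no measured neighbour to be ranked against. Compound 3 `CCCCCCCCCCCCCCNC(=O)c1c[nH]c(-c2ccccc2)n1` differs from compound 2 by a single change, ethyl in place of hydrogen on a saturated chain carbon, ten or more bonds along the chain from an amide-type nitrogen and the shared core stays untouched. Among the compounds with values here, the one measured step bearing on this is the identical change one stage shorter, recorded as a number no higher from compound 1 to compound 2 (the limit leaves the size open) and it gives a weak hint of direction but no size. A modest move towards a lower number in this assay is therefore expected, although a result within the scatter, or another limit, would not be surprising. The expected size is a 2.0-fold lower number from compound 2 to compound 3 (0.30 log units; within the scatter) on this estimate. For compound 3 the estimated value is 15000 nM with an expected range from 4000 nM to 30000 nM in this assay.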

Compound 3, half-maximal inhibitory concentration: 38200 nM
For compound 3 the middle estimate is 2.5-fold (0.41 log units) below the measured one; the whole stated range lies below it.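

In this assay, going by these compounds alone, the change of ethyl in place of hydrogen on a saturated chain carbon, ten or more bonds along the chain from an amide-type nitrogen, now has a readable size for the first time, and that size lies within the scatter: a 1.3-fold higher number from compound 2 to compound 3 (0.10 log units; within the scatter). Compound 1 remains a limit of the assay at > 30000 nM, and the steps that start from it cannot be read. The weak hint of direction from the shorter stage therefore finds no support in the one readable pair, which shows no resolved effect of this chain extension on the number, and the reading of the series stays narrow: the limit of > 30000 nM in this assay, at which 1 of the 3 values shown sits.

From the compounds shown here alone, whether a longer chain than that of compound 3, or an amine or a carboxylic acid at the far end of the chain, would move the number in this assay beyond the scatter remains open. Also open is whether any change to the amide or to the shared core would do so, since all the steps shown lie on the saturated chain.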